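Trimethoxyphenyl series: replacing the second aryl group

A few compounds are considered here, and "the series" means these few. Any claim that something is new, unique, unknown or untested is made for them only; others in the source may bear on it.

Measured in a functional assay on HCT-116 cells (Homo sapiens) for inhibition, read by CCK-8 assay, with a stated time of 48 h; on this read-out lower numbers stand for stronger inhibition and higher numbers for weaker inhibition:
compound 1 `COc1cc(-c2cc3nccc(-c4cc(OC)c(OC)c(OC)c4)n3n2)cc(OC)c1OC` gives > 10000 nM, a limit of the assay and not a number.
compound 2 `COc1cc(-c2ccnc3cc(-c4ccc5c(ccn5C)c4)nn23)cc(OC)c1OC` gives 39 nM.
compound 3 `COc1cc(-c2ccnc3cc(-c4cccc5c4ccn5CO)nn23)cc(OC)c1OC` gives 861 nM.

Compound 2 stands lowest of the two numbers shown; compound 3 is the nearest and its gap to compound 2 lies beyond the usual scatter. For compound 1 only the limit of > 10000 nM in this assay, at which 1 of the 3 values shown sits, is known. No pair of these compounds differs in one place alone, so no single step has been measured, and the numbers only show that the group carried on the core of compound 2 matters to the read-out.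

Compound 4 `COc1ccc(-c2cc3nccc(-c4cc(OC)c(OC)c(OC)c4)n3n2)cc1N` is the next one to be measured. Against compound 2 the change is 3-amino-4-methoxyphenyl in place of 1-methyl-1H-indol-5-yl on an aromatic carbon.

Within the data shown here, with no measured step of this kind to lean on, the expectation for this assay is a modest step in the weaker direction, which may yet fall within the scatter: the step of a 2.3-fold higher number from compound 2 to compound 4 (0.36 log units; beyond the scatter) is what is estimated here. For compound 4 the estimated value is 90 nM, with a range from 15 nM to 700 nM.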

Compound 4, half-maximal inhibitory concentration: 251 nM
Compound 4: the middle estimate sits 2.8-fold (0.45 log units) below what was measured; the range from low to high includes it.
By their numbers in this assay, from the lowest: compound 2; then compound 4; then compound 3. At a limit, above all of these: compound 1.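

In this assay, among these compounds, putting 3-amino-4-methoxyphenyl in place of 1-methyl-1H-indol-5-yl on this aromatic carbon gives a 6.4-fold higher number from compound 2 to compound 4 (0.81 log units; beyond the scatter), the only single change that can be read at this place so far. The two-ring 1-methyl-1H-indol-5-yl group is therefore not needed for a measurable value here, although compound 2 keeps the lower number. Compound 1, with a trimethoxyphenyl group at this place, gives a limit of the assay and not a number: the limit of > 10000 nM in this assay, at which 1 of the 4 values shown sits.

The compounds shown do not separate the share of the amino group from that of the methoxy group in compound 4. Also open, from the compounds shown here alone, is how a hydroxyl or dimethylamino group in place of that amino group, or a 1H-indol-5-yl group without the methyl, would read in this assay.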